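From methylsulfanyl to cyano on the shared core

The source may report more compounds than this note shows. Statements on the series, on what has been measured and on what is new or still open speak of the compounds shown alone.

Of the compounds shown here, three with one shared core have been tested in a functional assay on SK-MEL-28 cells (Homo sapiens) for inhibition, read by MTT assay, with a stated time of 48 h; on this read-out lower numbers stand for stronger inhibition and higher numbers for weaker inhibition. Compound 1 `CS(=O)(=O)c1ccc(-c2nc3ccccn3c2Sc2ccccc2)cc1` gives 61900 nM and compound 3 `CSc1ccc(-c2nc3ccccn3c2Sc2ccccc2)cc1` gives 67700 nM, two numbers that lie within the scatter of each other. Compound 2 `Cc1ccc(-c2nc3ccccn3c2Sc2ccccc2)cc1` gives > 100000 nM, which is a limit of the assay and not a number.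

Compound 4 `N#Cc1ccc(-c2nc3ccccn3c2Sc2ccccc2)cc1` has cyano in place of methylsulfanyl on an aromatic carbon, para to a large group: cyano in place of methylsulfanyl on an aromatic carbon. This exact swap has not been measured, so the closest guide is what other swaps on an aromatic carbon did. Putting methylsulfanyl in place of methylsulfonyl gave a 1.1-fold higher number from compound 1 to compound 3 (0.04 log units; within the scatter). Putting methyl in place of methylsulfonyl gave an at least 1.6-fold higher number from compound 1 to compound 2 (0.20 log units; that floor lies within the scatter), and putting methylsulfanyl in place of methyl gave an at least 1.4-fold lower number from compound 2 to compound 3 (0.16 log units; that floor lies within the scatter). The last two are only floors, so the true steps could be larger.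

Within the data shown here, with no measured step clearly beyond the scatter, none is expected in this assay here. The expected change is a 1.1-fold higher number from compound 3 to compound 4 (0.04 log units; within the scatter). Compound 4 could also reach (the limit of > 100000 nM in this assay, at which 1 of the 3 values shown sits). Compound 4 is estimated at 75000 nM, with an expected range from 38000 nM to 150000 nM.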

Compound 4, half-maximal inhibitory concentration: 67500 nM
Compound 4: the middle estimate sits 1.1-fold (0.05 log units) above what was measured; measured number inside the range.
By their numbers in this assay, from the lowest: compounds 1, 4 and 3 (each within the scatter of the next). At a limit, above all of these: compound 2.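

On this aromatic carbon, para to a large group, cyano joins methylsulfanyl and methylsulfonyl as a third group that this assay cannot separate from the others, with a 1.0-fold lower number from compound 3 to compound 4 (0.00 log units; within the scatter) and a 1.1-fold higher number from compound 1 to compound 4 (0.04 log units; within the scatter). Cyano in place of methyl reads an at least 1.4-fold lower number from compound 2 to compound 4 (0.17 log units; that floor lies within the scatter), so even the only comparison with a group that gave no number yields a floor inside the scatter, though the true step could be larger. Compound 2 remains the only compound given as a limit rather than a number: the limit of > 100000 nM in this assay, at which 1 of the 4 values shown sits.

What the compounds shown leave open is whether any group at this position can give a number clearly beyond the scatter of compound 1, compound 3 and compound 4, and an amine or a carboxylic acid here would put that to the test. Replacing the phenyl group on the sulfur of the shared core, which is the same in all of them, is a separate question that these compounds do not address.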